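Swapping chloro for methoxy on the second ring

This account rests on a few compounds, and the source may have more. Where it says the series, first, only, none or still open, it means among the compounds named here.

Compound 1 `COc1ccc(Cn2cc(CNC(=O)c3cn(-c4ccccc4)nc3-c3ccc(Cl)cc3)nn2)cc1` is the weaker of the two measured compounds: in a functional assay on HeLa cells (Homo sapiens) for antiproliferative activity, read by sulforhodamine B assay, with a stated time of 48 h (on this read-out higher numbers stand for weaker inhibition of growth and lower numbers for stronger inhibition of growth), compound 1 gives 1400 nM, while compound 2 `COc1ccc(Cn2cc(CNC(=O)c3cn(-c4ccccc4)nc3-c3ccc(Cl)cc3)nn2)cc1OC` gives 200 nM. Among the compounds with values here, the only measured step, a 7.0-fold lower number from compound 1 to compound 2 (0.85 log units; beyond the scatter), involves methoxy in place of hydrogen on an aromatic carbon, a different place from the change now considered. Within the data shown here, compound 3 `COc1ccc(Cn2cc(CNC(=O)c3cn(-c4ccccc4)nc3-c3ccc(OC)cc3)nn2)cc1` differs from compound 1 by methoxy in place of chloro on an aromatic carbon; no measured step speaks to this swap. With nothing to anchor a direction, compound 3 is expected to show a 1.4-fold higher number from compound 1 to compound 3 (0.15 log units; within the scatter), a step within the scatter. Compound 3 is therefore estimated at 2000 nM, with a range from 600 nM to 7000 nM.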

Compound 3, concentration for 50% growth inhibition: 450 nM
Compound 3: the middle estimate sits 4.4-fold (0.65 log units) above what was measured; measured number below the stated range.
By their numbers in this assay, from the lowest: compound 2; then compound 3; then compound 1.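

Changing 4-chlorophenyl to 4-methoxyphenyl is not a neutral swap: in this assay it gives a 3.1-fold lower number from compound 1 to compound 3 (0.49 log units; beyond the scatter) and so moves the number beyond the scatter. The position para to a large group therefore responds to what it carries, and of these two groups methoxy gives the stronger inhibition of growth. No measurement here offers an explanation for this difference. From the compounds shown here alone, whether an amine, a hydroxyl group or a longer chain at this position would lower the number further remains open. So does whether this gain would add to the one seen with the extra methoxy of compound 2.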